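Removing the nonyl group from compound 2

The source may report more compounds than this note shows. Statements on the series, on what has been measured and on what is new or still open speak of the compounds shown alone.

Measured so far, in an ADME assay on MRC5 cells (Homo sapiens) for cytotoxicity, read by MTT assay, with a stated time of 48 h; a lower number here means a stronger inhibitor, a higher number a weaker inhibitor:
- compound 1 `Cc1ccc(S(=O)(=O)N2CC2(CO[C@@H]2O[C@@H]3CO[C@H](c4ccccc4)O[C@@H]3[C@H](OCc3ccccc3)[C@H]2OCc2ccccc2)c2ccccc2)cc1` gives 570000 nM
- compound 2 `CCCCCCCCCC1(CO[C@@H]2O[C@@H]3CO[C@H](c4ccccc4)O[C@@H]3[C@H](OCc3ccccc3)[C@H]2OCc2ccccc2)CN1S(=O)(=O)c1ccc(C)cc1` gives 575000 nM

Going by the values given here, compound 2 holds the highest of these two numbers in this assay, but its nearest neighbour is compound 1, and the single measured step, a 1.0-fold higher number from compound 1 to compound 2 (0.00 log units; within the scatter), lies within the scatter, so the two compounds cannot be told apart on these data. Compound 3 `Cc1ccc(S(=O)(=O)N2CC2CO[C@@H]2O[C@@H]3CO[C@H](c4ccccc4)O[C@@H]3[C@H](OCc3ccccc3)[C@H]2OCc2ccccc2)cc1` is the compound still to be measured. It differs from compound 2 in one place: hydrogen in place of nonyl on a saturated ring carbon. Among the compounds with values here, the only measured step that bears on this position is a 1.0-fold higher number from compound 1 to compound 2 (0.00 log units; within the scatter), in which one substituent on that same saturated ring carbon gave way to another without a shift beyond the scatter. Nothing in these data shows that the group at this ring carbon moves the number in this assay, so for compound 3 a step of about a 1.0-fold lower number from compound 2 to compound 3 (0.00 log units; within the scatter) is expected, which is none beyond the scatter. The estimate for compound 3 in this assay is therefore 570000 nM, with a range from 300000 nM to 1100000 nM.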

Compound 3, half-maximal inhibitory concentration: 183000 nM
For compound 3 the middle estimate is 3.1-fold (0.49 log units) above the measured one; measured number outside the range, below it.
By their numbers in this assay, from the lowest: compound 3; then compounds 1 and 2 (each within the scatter of the next).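

In this assay the saturated ring carbon, which had looked indifferent when phenyl and nonyl could not be told apart, now proves able to move the number: hydrogen in place of nonyl gives a 3.1-fold lower number from compound 2 to compound 3 (0.50 log units; beyond the scatter) and hydrogen in place of phenyl gives a 3.1-fold lower number from compound 1 to compound 3 (0.49 log units; beyond the scatter) on the same carbon. Both steps are modest and run the same way, so among these three compounds the divide lies between a substituted and an unsubstituted ring carbon, not between the two substituents, however different phenyl and nonyl are in kind. No measurement shown here accounts for this shift, and its origin stays unexplained.

The compounds shown leave open whether a small group such as methyl or ethyl at this ring carbon would already give a number like those of compound 1 and compound 2, or whether only hydrogen gives the lower number, and how an amine or a carboxylic acid at the same place would behave. They also leave open whether the step would survive on a core carrying free hydroxyl groups in place of the benzyl ethers.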